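Fluoro for Methyl on a Sulfonamide at the Limit

A few compounds are considered here, and "the series" means these few. Any claim that something is new, unique, unknown or untested is made for them only; others in the source may bear on it.

Compound 1, `Cc1ccc(S(=O)(=O)Nc2ccc(-c3nc4ccccc4o3)cc2)cc1`, was tested in an assay on isolated protein for inhibition of malate dehydrogenase, mitochondrial (Sus scrofa), with stated times of 45 min and 30 min; on this read-out lower numbers stand for stronger inhibition and higher numbers for weaker inhibition. In this assay compound 1 gives only a limit, > 63000 nM, and no number. Compound 2, `O=S(=O)(Nc1ccc2oc(-c3ccccc3)nc2c1)c1ccc(Cl)cc1`, likewise returns only a limit in this assay, > 63000 nM. The picture so far is therefore (the limit of > 63000 nM in this assay, at which 2 of the 2 values shown sit), so compound 1 stands at the weak end of what this assay can report, with no number by which to rank it against any other compound. Compound 3, `O=S(=O)(Nc1ccc(-c2nc3ccccc3o2)cc1)c1ccc(F)cc1`, differs from compound 1 in one place: fluoro in place of methyl on an aromatic carbon. Among the measured compounds shown here, no measured pair shows what such a change does, and both measured compounds sit at the limit, so no direction can be read from the data. The estimated step, a step that the limit leaves unreadable from compound 1 to compound 3, is expected to be none beyond the scatter, and compound 3 is expected to return a limit rather than a number. Compound 3 is accordingly estimated at 90000 nM, within 30000 nM to 300000 nM.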

Compound 3, half-maximal inhibitory concentration: > 63000 nM
Compound 3 ended at the assay's limit; the forecaster's own chance of this, stated with the estimate: 85%; the middle value does not contradict the limit.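

Among the compounds shown here, compound 1 and compound 3 both return only a limit, so no step between them can be read: the limit of > 63000 nM in this assay, at which 3 of the 3 values shown sit. The compounds shown leave open what fluoro in place of methyl does to inhibition, and how any of these compounds ranks against another.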